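Homolog step on the phenylalkyl chain of compound 2

The compounds below may be only part of what the source reports. "The series", "measured", "known", "first", "only" and "open" are said of these compounds alone.

Measured so far in an in vitro functional assay on HEK ts201 cells for antagonist activity at Neuronal acetylcholine receptor; alpha4/beta2 (Homo sapiens), read by fluorescence and calcium flux; a higher number here means a weaker inhibitor, a lower number a stronger inhibitor:
- compound 1, `[N-]=[N+]=NCCCN1CCCC(COC(=O)c2ccccc2-c2ccccc2)C1`, gives 4270 nM
- compound 2, `CC1CC(=O)N(c2ccccc2C(=O)OCC2CCCN(CCCCCc3ccccc3)C2)C1=O`, gives 24500 nM
- compound 3, `O=C(Nc1cccc2ccccc12)c1ccccc1-c1ccccc1`, gives 10700 nM

Compound 2 stands at the highest number of the three; compound 3 is nearest, with a gap beyond the scatter, and compound 1 is furthest, also beyond the scatter. Among the measured compounds shown here, compound 3 shares only the core with compound 2, and compound 1 shares the core and the ring amine but not the chain, so neither pair shows a single clean step; no step between measured compounds is known.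

Compound 4, `CC1CC(=O)N(c2ccccc2C(=O)OCC2CCCN(CCCCCCc3ccccc3)C2)C1=O`, differs from compound 2 by benzyl in place of phenyl on a saturated chain carbon, five bonds along the chain from an amine nitrogen in a ring. The chain is extended by one unit, and nothing else moves. With no measured step of this kind in the series, a change in this assay within the scatter is expected, with no direction claimed. Compound 4 is therefore estimated at 20000 nM, range 7000 nM to 60000 nM, which is an expected step of a 1.2-fold lower number from compound 2 to compound 4 (0.09 log units; within the scatter).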

Compound 4, half-maximal inhibitory concentration: 29500 nM
For compound 4 the middle estimate is 1.5-fold (0.17 log units) below the measured one; the measured number falls inside the stated range.
By their numbers in this assay, from the lowest: compound 1; then compound 3; then compounds 2 and 4 (each within the scatter of the next).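

In this assay, among the compounds shown here, benzyl in place of phenyl on a saturated chain carbon, five bonds along the chain from an amine nitrogen in a ring, gives a 1.2-fold higher number from compound 2 to compound 4 (0.08 log units; within the scatter), which is the first step that changes a single place. At this position, one added chain unit therefore produces no readable shift in the number, and compound 2 and compound 4 cannot be told apart in this assay. Nothing measured here accounts for this result.

Still open, going by these compounds, is whether a shorter chain such as 3-phenylpropyl, a longer chain, or an amine or carboxylic acid at the chain end would shift the number beyond the scatter. One step also cannot show whether chain length matters at this position in compounds with a different group on the shared core.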